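The source may hold more compounds than are shown below. What is called first, only, known or untested is meant among the compounds shown, and "the series" means these compounds.

Three ureas sharing one core have been measured in an ADME assay on the whole organism for cytotoxicity, with Artemia salina as the target, with a stated time of 24 h; on this read-out higher numbers stand for an effect only at larger amounts of compound and lower numbers for an effect already at smaller amounts. Compound 1 `Cc1ccc(S(=O)(=O)NC(=O)Nc2ccccc2C(=O)/C=C/c2ccc(N(C)C)cc2)cc1` gives 38.1 ug/mL, compound 2 `CCc1cc(/C=C/C(=O)c2ccccc2NC(=O)NS(=O)(=O)c2ccc(C)cc2)cc(OC)c1OC` gives 19.2 ug/mL, and compound 3 `Cc1ccc(S(=O)(=O)NC(=O)Nc2ccccc2C(=O)/C=C/c2ccccc2O)cc1` gives 32.3 ug/mL. In this assay compound 3 stands second highest of the three numbers, with compound 1 nearest and compound 2 furthest, and every step among them lies within the scatter: a 2.0-fold lower number from compound 1 to compound 2 (0.30 log units; within the scatter), a 1.2-fold lower number from compound 1 to compound 3 (0.07 log units; within the scatter), a 1.7-fold higher number from compound 2 to compound 3 (0.23 log units; within the scatter).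

Compound 4 `Cc1ccc(S(=O)(=O)NC(=O)Nc2ccccc2C(=O)/C=C/c2ccccc2[N+](=O)[O-])cc1` follows from compound 3 by one change, (nitro in place of hydroxy on an aromatic carbon). Going by the values given here, no measured pair exchanges hydroxy for nitro, so none bears directly on this step. What the measured steps show is that swapping the whole aryl group on the double-bonded chain carbon, in the steps from compound 1 to compound 3 and from compound 2 to compound 3, moved this assay by amounts within the scatter. A smaller exchange at one aromatic carbon is therefore expected to do no more, with no step beyond the scatter in either direction, that is a 1.1-fold lower number from compound 3 to compound 4 (0.03 log units; within the scatter).

For compound 4 the expected value in this assay is 30 ug/mL, with a range from 15 ug/mL to 60 ug/mL.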

Compound 4, concentration for half-maximal effect: 40.1 ug/mL
Estimate against measurement, compound 4: 1.3-fold (0.13 log units) below; the range from low to high includes it.
By their numbers in this assay, from the lowest: compounds 2, 3, 1 and 4 (each within the scatter of the next, the first and the last beyond it).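

Going by these compounds alone, the exchange of hydroxy for nitro on an aromatic carbon ortho to a large group gives the first direct reading at this position: in this assay the step is a 1.2-fold higher number from compound 3 to compound 4 (0.09 log units; within the scatter), so here the hydrogen-bond donor of hydroxy leaves and the larger nitro enters without the number moving beyond the scatter, and the exchange of the whole aryl group gives a 1.1-fold higher number from compound 1 to compound 4 (0.02 log units; within the scatter). The step of a 2.1-fold higher number from compound 2 to compound 4 (0.32 log units; beyond the scatter) is the first among these compounds to lie beyond the scatter, though only modestly, so exchanging the whole aryl group on the double-bonded chain carbon can shift this read-out slightly, unlike any of the earlier steps. No measurement at hand accounts for either result.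

As far as these compounds go, whether an amine or a carboxylic acid on this same aromatic carbon would also stay within the scatter of compound 3 remains open. Every compound shown keeps the shared core unchanged, so it is also open how this assay would respond to a longer chain between that core and the aryl group.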